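A few compounds are considered here, and "the series" means these few. Any claim that something is new, unique, unknown or untested is made for them only; others in the source may bear on it.

For the measured compounds named here, compound 1 `Cc1ncc([N+](=O)[O-])n1CCCCCCBr` is the only member of the set with a numerical read-out: in an ADME assay on J774 cells (Mus musculus) for cytotoxicity, read by resazurin assay, with a stated time of 24 h (on this read-out lower numbers stand for stronger inhibition and higher numbers for weaker inhibition), compound 1 gives 69.9 ug/mL. Compound 2 `Cc1ncc([N+](=O)[O-])n1CCCCCN1CCCCC1` is reported at the limit of this assay, > 100 ug/mL. Compound 3 `Cc1ncc([N+](=O)[O-])n1CCCN1CCCC1` is likewise reported at the limit, > 100 ug/mL. Both measured steps, an at least 1.4-fold higher number from compound 1 to compound 2 (0.15 log units; that floor lies within the scatter) and an at least 1.4-fold higher number from compound 1 to compound 3 (0.15 log units; that floor lies within the scatter), therefore run from the number of compound 1 up to the limit, and each replaces a bromine-bearing chain end with a ring nitrogen. The limit itself is the main evidence on these steps (the limit of > 100 ug/mL in this assay, at which 2 of the 3 values shown sit). Compound 4 `Cc1ncc([N+](=O)[O-])n1CCCCCN1CCCC1` differs from compound 1 by pyrrolidin-1-yl in place of bromomethyl on a saturated chain carbon, five bonds along the chain from an aromatic nitrogen, so it combines the chain length of compound 2 with the ring of compound 3. Because an at least 1.4-fold higher number from compound 1 to compound 2 (0.15 log units; that floor lies within the scatter) and an at least 1.4-fold higher number from compound 1 to compound 3 (0.15 log units; that floor lies within the scatter) both reach the limit, the step from compound 1 to compound 4 is expected to run the same way, a 2.1-fold higher number from compound 1 to compound 4 (0.33 log units; beyond the scatter), towards weaker inhibition. Compound 4 is thus estimated at 150 ug/mL, with a range of 80 ug/mL to 300 ug/mL, most probably reported only as a limit.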

Compound 4, half-maximal inhibitory concentration: > 100 ug/mL
Compound 4: only a limit was reported; the forecaster's own chance of this, stated with the estimate: 75%; the middle value does not contradict the limit.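

With the chain held at five bonds from the aromatic nitrogen, pyrrolidin-1-yl in place of bromomethyl gives an at least 1.4-fold higher number from compound 1 to compound 4 (0.15 log units; that floor lies within the scatter) in this assay. The pyrrolidin-1-yl end now reaches the limit at two chain lengths, in compound 3 and compound 4, and the five-bond chain reaches it with two rings, in compound 2 and compound 4. Any difference between the two rings stays unreadable, because compound 2 and compound 4 are both limits rather than numbers: the limit of > 100 ug/mL in this assay, at which 3 of the 4 values shown sit.

From the compounds shown here alone, it remains open whether a morpholine ring or an open-chain amine such as diethylamino at the same chain end would also stay at the limit. A bromine end on the shorter chain of compound 3 would show how far chain length alone moves the number.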